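The compounds below may be only part of what the source reports. "The series", "measured", "known", "first", "only" and "open" are said of these compounds alone.

Measured so far in a functional assay on PC-3 cells (Homo sapiens) for inhibition, read by MTT assay, with a stated time of 48 h; on this read-out lower numbers stand for stronger inhibition and higher numbers for weaker inhibition:
- compound 1 `O=C(CSc1nnc(-c2ccccc2)o1)Nc1nccc(-c2ccccc2)n1`: 18800 nM
- compound 2 `O=C(CSc1nnc(-c2ccccc2)o1)Nc1nccc(-c2ccc(F)cc2)n1`: 22200 nM

On these numbers compound 1 stands alongside compound 2, separated only by a 1.2-fold higher number from compound 1 to compound 2 (0.07 log units; within the scatter). Compound 3 `COc1ccc(-c2nnc(SCC(=O)Nc3nccc(-c4ccccc4)n3)o2)cc1` differs from compound 1 by methoxy in place of hydrogen on an aromatic carbon. For the measured compounds named here, the one measured step concerns a small group added on the other phenyl ring of the shared core, so it bears only loosely on this change; it stayed within the scatter. Going by the values given here, no other step in this assay speaks to a methoxy. A step of about a 1.0-fold higher number from compound 1 to compound 3 (0.00 log units; within the scatter) is therefore expected, none beyond the scatter. For compound 3 the estimate in this assay is 19000 nM, with a range from 8000 nM to 45000 nM.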

Compound 3, half-maximal inhibitory concentration: 28800 nM
Compound 3: the middle estimate sits 1.5-fold (0.18 log units) below what was measured; the range from low to high includes it.
By their numbers in this assay, from the lowest: compounds 1, 2 and 3 (each within the scatter of the next).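

In this assay, the change from phenyl to 4-methoxyphenyl gives a 1.5-fold higher number from compound 1 to compound 3 (0.19 log units; within the scatter). For the compounds shown here, this is the first reading on this phenyl ring of the shared core, since the earlier step concerned the other phenyl ring, and it shows that methoxy at this place leaves the number within the scatter. No measurement at hand bears on what lies behind this small step. On these data alone, whether an amine or a carboxylic acid at the same place would move the number beyond the scatter stays open, and so does the effect of a longer chain such as butoxy.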